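From 4-chlorophenyl to 2-fluorophenyl on the same nitrogen

The source may report more compounds than this note shows. Statements on the series, on what has been measured and on what is new or still open speak of the compounds shown alone.

In a functional assay on A549 cells (Homo sapiens) for antiproliferative activity, read by MTT assay, with a stated time of 72 h (a higher number here means a weaker inhibitor, a lower number a stronger inhibitor), three compounds sharing one core have been measured, and they differ in the group on an amine nitrogen in a ring. Compound 1 `CN1CCN(C(=S)SCc2ccc3nc(N)nc(N)c3c2)CC1` gives 9200 nM with methyl there. Compound 2 `Nc1nc(N)c2cc(CSC(=S)N3CCN(c4ccccc4)CC3)ccc2n1` gives 2970 nM with phenyl there. Compound 3 `Nc1nc(N)c2cc(CSC(=S)N3CCN(c4ccc(Cl)cc4)CC3)ccc2n1` gives 5210 nM with 4-chlorophenyl there, a number that falls between the other two and within the scatter of each.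

Compound 4 `Nc1nc(N)c2cc(CSC(=S)N3CCN(c4ccccc4F)CC3)ccc2n1` has not yet been measured. It carries 2-fluorophenyl in place of 4-chlorophenyl on that nitrogen 2-fluorophenyl in place of 4-chlorophenyl on an amine nitrogen in a ring and is otherwise the same as compound 3.

Among the compounds with values here, replacing methyl with phenyl gave a 3.1-fold lower number from compound 1 to compound 2 (0.49 log units; beyond the scatter) and is the only modest step seen so far. Replacing methyl with 4-chlorophenyl gave a 1.8-fold lower number from compound 1 to compound 3 (0.25 log units; within the scatter) as a smaller change. The closest guide is the chloro added to the phenyl ring, which gave a 1.8-fold higher number from compound 2 to compound 3 (0.24 log units; within the scatter) and so barely moved the number. Within the data shown here, no measured compound carries a 2-fluorophenyl group, so this guide is only indirect.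

In this assay the expected change is therefore small, a 1.3-fold lower number from compound 3 to compound 4 (0.11 log units; within the scatter) and no clear shift beyond the scatter. For compound 4 the estimate is 4000 nM with an expected range from 1800 nM to 9000 nM until the measurement arrives.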

Compound 4, half-maximal inhibitory concentration: 6460 nM
The estimate for compound 4 lay 1.6-fold (0.21 log units) below the measured number, within the range that was stated.
By their numbers in this assay, from the lowest: compounds 2, 3, 4 and 1 (each within the scatter of the next, the first and the last beyond it).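

In this assay, exchanging one halogen-bearing phenyl ring for the other gives a 1.2-fold higher number from compound 3 to compound 4 (0.09 log units; within the scatter), so 4-chlorophenyl and 2-fluorophenyl cannot be told apart on this nitrogen, even though the halogen and its place on the ring both change. Adding fluoro to the plain phenyl ring does give a readable but modest step, a 2.2-fold higher number from compound 2 to compound 4 (0.34 log units; beyond the scatter), while the comparison with the small methyl group gives a 1.4-fold lower number from compound 1 to compound 4 (0.15 log units; within the scatter), so compound 4 cannot be told apart from compound 1, and among the aryl groups shown only plain phenyl stands clearly apart from methyl. Nothing available here explains why these numbers fall as they do.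

Because compound 3 and compound 4 differ in both the halogen and its place, the compounds shown cannot say which of the two matters, or whether either matters at all. They also leave open how a benzyl group on the same nitrogen, or a methoxy group or a bromo group on the phenyl ring, would compare with plain phenyl.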